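The source may report more compounds than this note shows. Statements on the series, on what has been measured and on what is new or still open speak of the compounds shown alone.

Of the compounds shown here, three of a shared core have been tested in a toxicity assay on MT4 cells (Homo sapiens) for cytotoxicity, read by MTT assay; on this read-out higher numbers stand for lower toxicity in this test and lower numbers for higher toxicity in this test. Compound 1 `Cc1cc(-c2ccc(C#N)c(C#N)c2)ccc1Oc1cc(N)nc(Nc2ccc(C#N)cc2)n1` gives 76700 nM in this assay. Compound 2 `COc1cc(Oc2cc(N)nc(Nc3ccc(C#N)cc3)n2)ccc1-c1ccc(C#N)cc1` gives 12900 nM in this assay. Compound 3 `Cc1cc(-c2cccc(Cl)c2)cc(C)c1Oc1cc(N)nc(Nc2ccc(C#N)cc2)n1` gives 22300 nM in this assay. Among these three numbers compound 3 stands second highest: its nearest neighbour is compound 2, whose number is lower by an amount that falls within the usual scatter of repeated measurements, so the two cannot be told apart with confidence; its furthest neighbour is compound 1, whose number is higher by an amount beyond that scatter.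

The next compound, compound 4 `Cc1cc(-c2cccc(C#N)c2)cc(C)c1Oc1cc(N)nc(Nc2ccc(C#N)cc2)n1`, is yet to be measured in this assay. It differs from compound 3 in a single place: cyano in place of chloro on an aromatic carbon. Within the data shown here, no pair of measured compounds here differs by exactly this exchange, so there is no measured step to lean on. The three measured numbers do spread over a range that reaches beyond the scatter, but they differ from one another in several places at once, so no single change can be read from them.

A cyano in place of chloro is a modest exchange, and the expectation is a step of a 1.3-fold higher number from compound 3 to compound 4 (0.10 log units; within the scatter) of no more than the usual scatter, in no settled direction. The estimate for compound 4 in this assay is therefore 28000 nM, with a range from 10000 nM to 80000 nM.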

Compound 4, half-maximal cytotoxic concentration: 20200 nM
Compound 4: middle estimate off by 1.4-fold (0.14 log units), on the high side; the range from low to high includes it.
By their numbers in this assay, from the lowest: compounds 2, 4 and 3 (each within the scatter of the next); then compound 1.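

In this assay, putting cyano in place of chloro on this aromatic carbon, which turns 3-chlorophenyl into 3-cyanophenyl, gives a 1.1-fold lower number from compound 3 to compound 4 (0.04 log units; within the scatter), so the two compounds cannot be told apart on this read-out. Among these compounds, this is the first step that changes one place only. The earlier compounds shown here differ in several places at once, and this step gives what their numbers could not: a direct reading of a single exchange at this position. Here one chlorine leaves, a carbon and a nitrogen enter, a hydrogen-bond acceptor is added to the count, and the toxicity reading stays within the usual scatter, though nothing measured here accounts for that outcome.

What the compounds shown leave open is whether an amine, a carboxylic acid or a longer chain on the same aromatic carbon would also stay within the scatter, or would instead move the number beyond it. Also open, going by these compounds, is whether cyano in place of chloro would give so small a step on a different ring position or in a compound that differs elsewhere on the shared core.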